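Chloro in Place of Trifluoromethyl: Expecting Another Weak Inhibitor

A few compounds are considered here, and "the series" means these few. Any claim that something is new, unique, unknown or untested is made for them only; others in the source may bear on it.

Of the compounds shown here, three have so far been measured in an assay on cells for inhibition of HSP60/HSP10 (Homo sapiens), with a stated time of 60 min; on this read-out higher numbers stand for weaker inhibition and lower numbers for stronger inhibition. Compound 1 `Cc1ccccc1S(=O)(=O)Nc1ccc2oc(-c3ccccc3)nc2c1` returns only a limit of the assay, > 100000 nM. Compound 2 `O=S(=O)(Nc1ccc2oc(-c3ccccc3)nc2c1)c1ccccc1C(F)(F)F` likewise reaches only a limit, > 100000 nM. The step that the two limits leave unreadable from compound 1 to compound 2 consequently cannot be sized. Going by the values given here, compound 3 `O=S(=O)(Nc1ccc(-c2nc3ccccc3o2)cc1)c1ccc(C(F)(F)F)cc1` is the single member of the set with an actual number. In this assay compound 3 gives 50000 nM. Among the compounds with values here, this is the only value shown, since compounds 1 and 2 both sit at the limit of > 100000 nM in this assay, at which 2 of the 3 values shown sit.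

Compound 4 `O=S(=O)(Nc1ccc(-c2nc3ccccc3o2)cc1)c1ccc(Cl)cc1` differs from compound 3 in one place: chloro in place of trifluoromethyl on an aromatic carbon. Within the data shown here, no measured step involves this pair of groups. Among the measured compounds shown here, the only step that has been measured, trifluoromethyl in place of methyl, is of unreadable size, so it offers no guide to the present change. With nothing in the data pointing in either direction, the expectation for compound 4 is a potency close to that of compound 3, with no step beyond the usual scatter and a real chance that the assay again reports only a limit. Compound 4 is therefore estimated at 60000 nM, with a range from 20000 nM to 200000 nM. This estimate means an expected step of a 1.2-fold higher number from compound 3 to compound 4 (0.08 log units; within the scatter) that stays within the scatter of repeated measurements.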

Compound 4, half-maximal inhibitory concentration: 61000 nM
Compound 4: the middle estimate sits 1.0-fold (0.01 log units) below what was measured, within the range that was stated.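

Replacing trifluoromethyl with chloro on an aromatic carbon, para to a large group, gives in this assay a 1.2-fold higher number from compound 3 to compound 4 (0.09 log units; within the scatter), so the number does not separate these two groups at this position. The change takes the substituent from 4 heavy atoms to 1, and neither group has a hydrogen-bond donor, a hydrogen-bond acceptor, a ring or a net charge, so the smaller group, at least here, gives a value that cannot be told from that of the larger one. Going by these compounds alone, this is also the first step in the set with a real number at both ends, whereas the remaining two compounds stop at a limit of the assay: the limit of > 100000 nM in this assay, at which 2 of the 4 values shown sit.

The compounds shown leave open whether a different kind of group at this position, such as an amine, a carboxylic acid or a methoxy group, would move the number beyond the scatter. They also leave open whether chloro in place of trifluoromethyl would read the same way on the core of compound 2.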